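Ester to acid to acetate: a chain change on a shared core

The source may hold more compounds than are shown below. What is called first, only, known or untested is meant among the compounds shown, and "the series" means these compounds.

Compound 1, `COC(=O)CCn1c2ccc([N+](=O)[O-])cc2c(=O)n1Cc1ccccc1`, and compound 2, `O=C(O)CCCn1c2ccc([N+](=O)[O-])cc2c(=O)n1Cc1ccccc1`, share one core and differ only at the end of a short chain. In an ADME assay on L929 cells (Mus musculus) for cytotoxicity, read by resazurin assay, with a stated time of 48 h (on this read-out lower numbers stand for higher toxicity in this test and higher numbers for lower toxicity in this test), compound 1 gives > 256000 nM, which is a limit of the assay rather than a number. Compound 2 likewise gives > 256000 nM, again a limit. The step that the two limits leave unreadable from compound 1 to compound 2 is therefore unreadable, and both values sit at the limit of > 256000 nM in this assay, at which 2 of the 2 values shown sit. Compound 2 thus stands at the edge of what this assay can see. Compound 3, `CC(=O)OCCn1c2ccc([N+](=O)[O-])cc2c(=O)n1Cc1ccccc1`, differs from compound 2 by acetoxy in place of carboxymethyl on a saturated chain carbon, two bonds along the chain from an aromatic nitrogen. Among the compounds with values here, no measured step here can be read as a size, so no direction beyond the scatter can be drawn from it. The expected step is a step that the limit leaves unreadable from compound 2 to compound 3, with a good chance that only a limit is reported again. Compound 3 is estimated at 400000 nM, with a range from 150000 nM to 1200000 nM.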

Compound 3, concentration lethal to 50% of the cells: > 256000 nM
Compound 3 ended at the assay's limit; the forecaster's own chance of this, stated with the estimate: 80%; the middle value does not contradict the limit.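

In this assay compound 3 gives > 256000 nM, which is a limit and not a number. Within the data shown here, no step among compound 1, compound 2 and compound 3 can be read: the limit of > 256000 nM in this assay, at which 3 of the 3 values shown sit. The compounds shown leave open whether these three chain ends differ at all in toxicity to these cells.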